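The compounds below may be only part of what the source reports. "The series", "measured", "known", "first", "only" and "open" are said of these compounds alone.

Working notes on the series. Compound 1 is `C[C@@H](CO)Nc1nc(C(=O)NCc2ccc(F)cc2)c(O)c2ncccc12`; in a functional assay on HCT-116 cells (Homo sapiens) for cytotoxicity, read by MTT assay, with a stated time of 72 h (on this read-out lower numbers stand for stronger inhibition and higher numbers for weaker inhibition), compound 1 gives "not determined" (no result reported). Compound 2 is `NCCCNc1c(C(=O)NCc2ccc(F)cc2)ncc2cccnc12`. In this assay compound 2 returns only a limit, > 10000 nM, not a number. Compound 3 is `NCCNc1c(C(=O)NCc2ccc(F)cc2)nc(Br)c2cccnc12`. In this assay compound 3 likewise returns a limit, > 20000 nM, rather than a number. On the numbers shown, compound 3 therefore has no fixed place: its own entry is a limit, (the limit of > 20000 nM in this assay, at which 1 of the 3 values shown sits), one further entry is a limit, (the limit of > 10000 nM in this assay, at which 1 of the 3 values shown sits), and the remaining entry carries no number at all. Among the measured compounds shown here, no two measured compounds differ in a single place, so no measured step is available to lean on.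

Compound 4 is `Cc1ccc(S(=O)(=O)Oc2c(C(=O)NCc3ccc(F)cc3)nc(Br)c3cccnc23)cc1`. It differs from compound 3 in one respect: ((4-methylphenyl)sulfonyl)oxy in place of (2-aminoethyl)amino on an aromatic carbon. The group that enters occupies the same aromatic carbon, ortho to a fused ring and para to a bromo group, that the leaving group held.

With only limits to work from, compounds 2 and 3 give no direction to read; the step of an at least 1.3-fold lower number from compound 3 to compound 4 (0.12 log units; that floor lies within the scatter) is therefore expected to be none beyond the scatter, most likely ending again at a limit. Compound 4 is expected at 15000 nM in this assay, between 3000 nM and 50000 nM.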

Compound 4, half-maximal inhibitory concentration: > 20000 nM
Compound 4: a limit, no number; the forecaster's own chance of this, stated with the estimate: 55%; at least 1.3-fold (0.12 log units) between middle value and limit.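

Compound 3 and compound 4 both return only a limit in this assay, so no step between them can be read; both stand at the same limit: the limit of > 20000 nM in this assay, at which 2 of the 4 values shown sit.

The compounds shown leave open whether ((4-methylphenyl)sulfonyl)oxy in place of (2-aminoethyl)amino on that aromatic carbon changes the result at all, and what a numerical value in this assay would look like for this series.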